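From propyl to 4-methylphenyl on a sulfonyl sulfur

A few compounds are considered here, and "the series" means these few. Any claim that something is new, unique, unknown or untested is made for them only; others in the source may bear on it.

Compound 1 `CCCS(=O)(=O)N1CCC2(CC1)OOC1(CCCC1)OO2`: > 100 ug/mL
Compound 2 `CCCS(=O)(=O)N1CCC2(CC1)OOC1(CCCCC1)OO2`: > 100 ug/mL
Compound 3 `CCCS(=O)(=O)N1CCC2(CC1)OOC1(CCCCCC1)OO2`: > 100 ug/mL

These three results come from a functional assay on Huh-7 cells (Homo sapiens) for cytotoxicity, read by MTT assay, with a stated time of 72 h (on this read-out lower numbers stand for higher toxicity in this test and higher numbers for lower toxicity in this test), and each one is a limit of the assay rather than a number. Compound 3 stands at the limit of > 100 ug/mL in this assay, at which 3 of the 3 values shown sit.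

Compound 4 `Cc1ccc(S(=O)(=O)N2CCC3(CC2)OOC2(CCCCCC2)OO3)cc1` carries 4-methylphenyl in place of propyl on a sulfonyl sulfur. For the measured compounds named here, no measured pair shows what this swap does. The expectation rests on compound 3, whose > 100 ug/mL is again only a limit, and no change beyond the scatter is expected in this assay. The expected a number no higher from compound 3 to compound 4 (the limit leaves the size open) is therefore small. Compound 4 is estimated at 100 ug/mL, with an expected range from 45 ug/mL to 200 ug/mL.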

Compound 4, half-maximal cytotoxic concentration: > 100 ug/mL
Compound 4: a limit, no number; the forecaster's own chance of this, stated with the estimate: 70%; the middle value sits exactly at the limit.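

In this assay, for the compounds shown here, compound 3 and compound 4 each give a limit of the assay rather than a number, so no step between them can be read: the limit of > 100 ug/mL in this assay, at which 4 of the 4 values shown sit. The compounds shown leave open whether 4-methylphenyl in place of propyl changes toxicity in these cells at all.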